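A few compounds are considered here, and "the series" means these few. Any claim that something is new, unique, unknown or untested is made for them only; others in the source may bear on it.

Compound 3 `COc1cc(Oc2cccc(Nc3ccccc3)c2)cc(OC)c1CNCc1ccc(C)cc1` carries a 4-methylbenzyl group on the shared core and gives in a functional assay on DLD-1 cells (Homo sapiens) for inhibition, read by MTT assay, with a stated time of 72 h (on this read-out lower numbers stand for stronger inhibition and higher numbers for weaker inhibition), a value of 6080 nM. Among the three numbers shown, compound 3 sits apart only from compound 1 `COc1ccc(CNCc2c(OC)cc(Oc3cccc(Nc4ccccc4)c3)cc2OC)cc1`, which in this assay gives 1910 nM; the step of a 3.2-fold higher number from compound 1 to compound 3 (0.50 log units; beyond the scatter) is modest but beyond the scatter. Compound 2 `COc1cc(Oc2cccc(Nc3ccccc3)c2)cc(OC)c1CNCc1ccccc1` gives 5220 nM in this assay, and the step of a 1.2-fold higher number from compound 2 to compound 3 (0.07 log units; within the scatter) stays within the scatter, so compound 2 and compound 3 cannot be ordered. The third step, a 2.7-fold higher number from compound 1 to compound 2 (0.44 log units; beyond the scatter), is again modest and beyond the scatter.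

Compound 4 `COc1cc(Oc2cccc(Nc3ccccc3)c2)cc(OC)c1CNCc1ccc(Cl)cc1` differs from compound 3 by chloro in place of methyl on an aromatic carbon. Among the compounds with values here, no measured step exchanges chloro for another group, so nothing bears on this change directly. What the recorded steps show is that hydrogen and methyl on this aromatic carbon gave numbers within the scatter of each other, while only methoxy stood apart. For compound 4 a number close to that of compound 3 is therefore expected, with the step of a 1.1-fold lower number from compound 3 to compound 4 (0.04 log units; within the scatter) expected to lie within or near the scatter. Compound 4 is estimated at 5500 nM in this assay, with a range from 2500 nM to 12000 nM.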

Compound 4, half-maximal inhibitory concentration: 3740 nM
Compound 4: the middle estimate sits 1.5-fold (0.17 log units) above what was measured; the range from low to high includes it.
By their numbers in this assay, from the lowest: compounds 1, 4, 2 and 3 (each within the scatter of the next, the first and the last beyond it).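

In this assay chloro on this aromatic carbon cannot be told apart from methyl (a 1.6-fold lower number from compound 3 to compound 4 (0.21 log units; within the scatter)) or from hydrogen (a 1.4-fold lower number from compound 2 to compound 4 (0.14 log units; within the scatter)), so compound 4 joins compound 2 and compound 3 in a group that cannot be ordered. The new finding is that chloro also cannot be told apart from methoxy (a 2.0-fold higher number from compound 1 to compound 4 (0.29 log units; within the scatter)), whereas hydrogen (a 2.7-fold higher number from compound 1 to compound 2 (0.44 log units; beyond the scatter)) and methyl (a 3.2-fold higher number from compound 1 to compound 3 (0.50 log units; beyond the scatter)) both stand apart from it, so among the four groups at this place methoxy is separated only from hydrogen and methyl, and the modest gap that set compound 1 apart no longer marks it off from every other compound. Nothing available explains why these numbers fall as they do.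

The compounds shown leave open whether a clearly different group at this place, such as an amine, a carboxylic acid or a nitrile, would give a number beyond the scatter of all four. They also leave open whether the small differences seen here would hold for the same compounds on other cell lines.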